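A few compounds are considered here, and "the series" means these few. Any claim that something is new, unique, unknown or untested is made for them only; others in the source may bear on it.

Measured so far in this series:

- compound 1, `CCc1ccnc(C(=O)Nc2nn[nH]n2)c1`: 32%
- compound 2, `O=C(Nc1nn[nH]n1)c1cc(Br)ccn1`: 9%

In a functional assay on the whole organism for inhibition, with Rattus norvegicus as the target, at a dose of 1 mg/kg by the oral route (a higher number here means a stronger effect of the compound at the dose given, a lower number a weaker effect), compound 2 stands lowest of the two numbers; its nearest neighbour is compound 1, and the step of a number 23 percentage points lower from compound 1 to compound 2 (beyond the scatter) is beyond the scatter.

Compound 3, `Cc1ccnc(C(=O)Nc2nn[nH]n2)c1`, is not yet measured. It differs from compound 2 in one place: methyl in place of bromo on an aromatic carbon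

For the measured compounds named here, the only measured step that bears on this change is the one between compound 1 and compound 2, where a bromo in place of an ethyl on the same aromatic carbon gave a number 23 percentage points lower from compound 1 to compound 2 (beyond the scatter). Methyl and ethyl are both small alkyl groups at that position, so putting methyl back in place of bromo is expected to reverse part of that loss, though how much of it is open.

For compound 3 the expected step is a number 16 percentage points higher from compound 2 to compound 3 (beyond the scatter) in this assay, an increase. Compound 3 is estimated at 25%, within 8% to 42%.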

Compound 3, a percentage reported as inhibition, in the whole organism at one dose (the size of the read-out at that dose, not a potency): 28%
Compound 3: middle estimate off by 3 percentage points, on the low side, and the stated range covers the measured number.
By their numbers in this assay, from the lowest: compound 2; then compounds 3 and 1 (each within the scatter of the next).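

In this assay, methyl in place of bromo on the aromatic carbon opposite the ring nitrogen gives a number 19 percentage points higher from compound 2 to compound 3 (beyond the scatter), so the low value of compound 2 now stands apart from two alkyl groups at this position, not from ethyl alone. Going the other way along the chain, hydrogen in place of methyl on the saturated chain carbon gives a number 4 percentage points lower from compound 1 to compound 3 (within the scatter), so methyl and ethyl cannot be told apart in this assay, and the extra chain carbon makes no readable difference. No measurement at hand accounts for the gap between bromo and the two alkyl groups.

Open, from the compounds shown here alone, is whether a longer chain such as propyl, a methoxy group or an amine at this carbon would separate from compound 1 and compound 3. Also open, going by these compounds, is what plain hydrogen there would give, and, with a single oral dose, how the compounds would compare across other doses.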